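The source may report more compounds than this note shows. Statements on the series, on what has been measured and on what is new or still open speak of the compounds shown alone.

Measured compounds:
compound 1 `COc1cc(NC(=O)Nc2cc(Nc3ccc(F)c(Cl)c3)ncn2)cc(OC)c1`, 36.7%
compound 2 `COc1cc(Br)ccc1Nc1cc(NC(=O)Nc2c(Cl)cccc2Cl)ncn1`, 43%
compound 3 `COc1ccc(C(F)(F)F)cc1Nc1cc(NC(=O)Nc2c(Cl)cccc2Cl)ncn1`, 60.1%

The three compounds share a core and were tested in a functional assay on NCI-H226 cells (Homo sapiens) for inhibition, read by MTT assay, with a stated time of 48 h, tested at 10 uM; a higher number here means more inhibition at the concentration tested (going by the name of the read-out), a lower number less inhibition. Compound 1 gives the lowest of the three numbers, 36.7%. Its nearest neighbour on the numbers is compound 2, whose value of 43% lies within the usual scatter of compound 1, so no order between the two can be claimed. Compound 3, with 60.1%, stands beyond the scatter above compound 1. Within the data shown here, no pair among the three differs in only one place, so none of these gaps can be tied to a single change.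

Compound 4 `COc1cc(NC(=O)Nc2cc(Nc3cc(C)cc(F)c3)ncn2)cc(OC)c1` has not yet been measured. It differs from compound 1 in one place: 3-fluoro-5-methylphenyl in place of 3-chloro-4-fluorophenyl on a nitrogen on an aromatic ring. Both groups that leave and enter are single six-membered aromatic rings of carbon of the same heavy-atom count, with no donors or acceptors and no charge. Among the measured compounds shown here, nothing among the measured compounds shows what such an exchange does in this assay, so the step from compound 1 to compound 4 is expected to be small, in either direction or none beyond the scatter, estimated as a number 1.7 percentage points lower from compound 1 to compound 4 (within the scatter). Compound 4 is therefore expected to give about 35% in this assay, between 20% and 52%.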

Compound 4, a percentage reported as inhibition, at one concentration (the size of the read-out at that concentration, not a potency): 35.3%
For compound 4 the middle estimate is 0.3 percentage points below the measured one; low and high end bracket the measured number.
By their numbers in this assay, from the lowest: compounds 4, 1 and 2 (each within the scatter of the next); then compound 3.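

In this assay, among these compounds, the exchange of 3-chloro-4-fluorophenyl for 3-fluoro-5-methylphenyl on a nitrogen on an aromatic ring gives the only step that can be read in this set, a number 1.4 percentage points lower from compound 1 to compound 4 (within the scatter). Among the compounds shown here, on the core of compound 1, this position therefore accepts this one exchange of aromatic groups of equal heavy-atom count, with the chlorine gone and a methyl present, without a change beyond the scatter, something the earlier compounds could not show because no pair among them differed in only one place. No measured evidence is available that would account for this result.

As far as these compounds go, the step covers only these two substituted phenyl groups, so it remains open whether a different kind of group at this place, such as a morpholine ring, an amine or a carboxylic acid on the phenyl ring, would move the number beyond the scatter. It also remains open which single change, if any, lies behind the higher number of compound 3 at 60.1%, since that compound is not linked to any other here by a one-place step.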